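The compounds below may be only part of what the source reports. "The series", "measured", "known", "first", "only" and "open" are said of these compounds alone.

Three compounds share a core and differ only in the group attached to an aromatic nitrogen. Compound 1 `CC1=C(CCCCCCCCCCn2cc(C[C@H](O)COCCOC[C@@H](O)Cc3ccc(-c4ccccc4)cc3)nn2)C(=O)c2ccccc2C1=O` gives 390 nM in a functional assay on SGC-7901 cells (Homo sapiens) for inhibition, read by MTT assay, with a stated time of 72 h; on this read-out lower numbers stand for stronger inhibition of growth and higher numbers for weaker inhibition of growth. Compound 3 `O[C@H](COCCOC[C@@H](O)Cc1cn(Cc2ccc(Oc3ccccc3)cc2)nn1)Cc1ccc(-c2ccccc2)cc1` gives 4500 nM in this assay. Compound 2 `O=C1COc2ccc(-n3cc(C[C@H](O)COCCOC[C@@H](O)Cc4ccc(-c5ccccc5)cc4)nn3)cc2N1` gives 15200 nM in this assay, the highest of the three numbers; its gap to compound 3 and its wider gap to compound 1 both lie beyond the scatter. Compound 4 `O[C@H](COCCOC[C@@H](O)Cc1cn(-c2ccc3[nH]ccc3c2)nn1)Cc1ccc(-c2ccccc2)cc1` has not yet been measured; it differs from compound 2 by a group of 9 heavy atoms (8 carbon, 1 nitrogen; one five-membered aromatic ring with 1 hetero atom, one six-membered aromatic ring of carbon only) in place of a group of 11 heavy atoms (8 carbon, 1 nitrogen, 2 oxygen; one six-membered non-aromatic ring with 2 hetero atoms, one six-membered aromatic ring of carbon only), on an aromatic nitrogen. Among the compounds with values here, no measured pair shows this change. Compound 4 is expected to give a lower number than compound 2, a step estimated at a 3.0-fold lower number from compound 2 to compound 4 (0.48 log units; beyond the scatter), since compound 3 reaches 4500 nM with another group on the aromatic nitrogen. The estimate for compound 4 is 5000 nM, with a range from 1500 nM to 16000 nM.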

Compound 4, concentration for 50% growth inhibition: 45600 nM
Compound 4: the middle estimate sits 9.1-fold (0.96 log units) below what was measured; the measured number lies above the stated range.
By their numbers in this assay, from the lowest: compound 1; then compound 3; then compound 2; then compound 4.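

With 1H-indol-5-yl on the aromatic nitrogen, this assay shows a 3.0-fold higher number from compound 2 to compound 4 (0.48 log units; beyond the scatter), the only direct step at this position among these compounds. It shows that a group with no non-aromatic ring and no oxygen atoms does not lower the number here, even though it is also the smaller group. No measurement shown accounts for this step. As far as these compounds go, it remains open whether 1H-indol-5-yl attached through a longer chain would give a lower number. From the compounds shown here alone, the effect of an amine or a carboxylic acid on this group also remains open.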